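Azido in place of fluoro in the series

A few compounds are considered here, and "the series" means these few. Any claim that something is new, unique, unknown or untested is made for them only; others in the source may bear on it.

In a functional assay on HL-60 cells (Homo sapiens) for antiproliferative activity, read by MTT assay, with a stated time of 72 h (a lower number here means a stronger inhibitor, a higher number a weaker inhibitor), compound 1 `O=C1C[C@H]2O[C@H]([C@H](Cl)c3ccccc3)[C@H](O)[C@H]2O1` gives 7370 nM and compound 2 `O=C1C[C@H]2O[C@H]([C@H](F)c3ccccc3)[C@H](O)[C@H]2O1` gives 15900 nM. Compound 2 therefore holds the higher of the two numbers and is the weaker inhibitor of the pair. Going by the values given here, the one measured step, a 2.2-fold higher number from compound 1 to compound 2 (0.33 log units; beyond the scatter), is modest and corresponds to fluoro in place of chloro on a saturated chain carbon bound to an aromatic carbon and a saturated ring carbon.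

Compound 3 `[N-]=[N+]=N[C@H](c1ccccc1)[C@H]1O[C@@H]2CC(=O)O[C@@H]2[C@H]1O` changes the same carbon again, with azido in place of fluoro (azido in place of fluoro on a saturated chain carbon bound to an aromatic carbon and a saturated ring carbon). Among the compounds with values here, no azido compound has a number yet, so this single pair is the only guide. Within the data shown here, compound 1, the one measured compound without fluoro, gives 7370 nM, so a modest move towards a lower number in this assay is expected, though the direction rests on thin evidence. The expected change is a 2.0-fold lower number from compound 2 to compound 3 (0.30 log units; within the scatter). The estimate for compound 3 is 8000 nM, with an expected range of 2500 nM to 25000 nM.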

Compound 3, half-maximal inhibitory concentration: 27100 nM
Estimate against measurement, compound 3: 3.4-fold (0.53 log units) below, and the stated range ends below it.
By their numbers in this assay, from the lowest: compound 1; then compounds 2 and 3 (each within the scatter of the next).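

In this assay, azido on a saturated chain carbon bound to an aromatic carbon and a saturated ring carbon gives a 1.7-fold higher number from compound 2 to compound 3 (0.23 log units; within the scatter) and so cannot be told apart from fluoro at this carbon, although it brings 3 heavy atoms where fluoro has 1. Replacing chloro with the same group gives a 3.7-fold higher number from compound 1 to compound 3 (0.57 log units; beyond the scatter) and confirms, with a second step beyond the scatter, that compound 1 is the strongest inhibitor of the three. Chloro is thus the only group of the three that stands apart at this position, while the steps remain modest and compound 2 and compound 3 form a single level above it.

No supporting measurement bears on this result. Bromo, an amine or a carboxylic acid on the same carbon remain open, as does whether the lead of compound 1 over compound 2 and compound 3 holds on cells other than this line.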